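Aryl tail change in a two-compound aorta series

A few compounds are considered here, and "the series" means these few. Any claim that something is new, unique, unknown or untested is made for them only; others in the source may bear on it.

Of the compounds shown here, two have numbers so far. Compound 1 `COc1cc(C(C)=O)ccc1OCCCN1CCC(C(c2ccc(F)cc2)C2CCCCC2)CC1` gives 5.01 nM in a functional assay (aorta) with Oryctolagus cuniculus as the target; on this read-out lower numbers stand for tighter binding and higher numbers for weaker binding. Compound 2 `CC(=O)c1ccc(OCCCN2CCC(C(c3ccc(F)cc3)c3ccc(F)cc3)CC2)cc1` gives 2.51 nM in this assay; this is the lower of the two numbers, but the gap to compound 1 lies within the scatter, so the two cannot be separated on these data. Within the data shown here, no measured pair differs in a single place, so no step size is known from the series itself.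

Compound 3 `Fc1ccc(C(c2ccc(F)cc2)C2CCN(CCCSc3ccccc3)CC2)cc1` has not yet been measured. It differs from compound 2 as follows: phenylsulfanyl in place of 4-acetylphenoxy on a saturated chain carbon, three bonds along the chain from an amine nitrogen in a ring. The chain and the ring amine are kept; the change is confined to the group at the chain end, where 4-acetylphenoxy leaves and phenylsulfanyl enters.

Among the measured compounds shown here, with no measured step to lean on, the step from compound 2 to compound 3 in this assay is expected to be a moderate move toward higher numbers, a 2.5-fold higher number from compound 2 to compound 3 (0.40 log units; beyond the scatter), though a result inside the scatter would not be surprising. Compound 3 is expected to give 6.3 nM in this assay, with a range from 1.6 nM to 25 nM.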

Compound 3, dissociation constant: 3.16 nM
Beside the measured number, compound 3's estimate is 2.0-fold (0.30 log units) above it; low and high end bracket the measured number.
By their numbers in this assay, from the lowest: compounds 2, 3 and 1 (each within the scatter of the next).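

Among these compounds, the step of a 1.3-fold higher number from compound 2 to compound 3 (0.10 log units; within the scatter) in this assay is the first single-place comparison, and it lies within the scatter. At this chain end, three bonds along the chain from an amine nitrogen in a ring, the exchange of 4-acetylphenoxy for phenylsulfanyl brings fewer heavy atoms, fewer hydrogen-bond acceptors, sulfur in place of oxygen and no double bond outside the aromatic ring, yet the read-out does not separate compound 2 from compound 3, so this change shows no measurable effect on these data. No measured property bears on this result, and no reason for it can be given.

From the compounds shown here alone, whether the same holds for a chain end without an aromatic ring, such as a carboxylic acid or a primary amine, or for a longer chain leading to the phenylsulfanyl group, remains open. An unsubstituted phenoxy group at this place would be needed to tell the exchange of oxygen for sulfur apart from the loss of the acetyl group, and the shown compounds leave that split unresolved.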